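Removing the side chain from compound 2

The source may report more compounds than this note shows. Statements on the series, on what has been measured and on what is new or still open speak of the compounds shown alone.

Compound 1 `N[C@@H]1C[C@H](N)[C@@]2(CC[C@@H](O)[C@@H](O)CO2)[C@H](O)[C@H]1O` gives 141000 nM
Compound 2 `NCC[C@H](O)C(=O)N[C@@H]1C[C@H](N)[C@@]2(CC[C@H](O)[C@H](O)CO2)[C@H](O)[C@H]1O` gives 6900 nM

In an assay on nucleic acid for binding affinity to Nucleic Acid, read by fluorescence (a lower number here means that less compound is needed, a higher number that more compound is needed for the effect), compound 2 gives 6900 nM as the lower of the two numbers, so less of it is needed for the effect. Compound 1 gives (141000 nM), and that gap lies beyond the scatter.

Compound 3 `N[C@@H]1C[C@H](N)[C@@]2(CC[C@H](O)[C@H](O)CO2)[C@H](O)[C@H]1O` has not yet been measured. It differs from compound 2 by a single change hydrogen in place of (3-amino-1-hydroxypropyl)carbonyl on an amine nitrogen with hydrogen in place of (3-amino-1-hydroxypropyl)carbonyl on an amine nitrogen. Going by the values given here, no measured pair shows this change alone, so there is no direct step to copy, and the expectation below is a judgement with a wide range.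

Losing this group is expected to raise the number in this assay, meaning that more compound would be needed. The expected move is a 13-fold higher number from compound 2 to compound 3 (1.12 log units; beyond the scatter) and would lie beyond the scatter. Among the compounds with values here, as a reference point for that expectation, compound 1 marks the high end of the numbers so far at (141000 nM). The estimated value for compound 3 is 90000 nM with an expected range (30000 nM to 250000 nM).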

Compound 3, half-maximal effective concentration: 74000 nM
The estimate for compound 3 lay 1.2-fold (0.09 log units) above the measured number, and the stated range covers the measured number.
By their numbers in this assay, from the lowest: compound 2; then compounds 3 and 1 (each within the scatter of the next).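

In this assay, the (3-amino-1-hydroxypropyl)carbonyl group on the amine nitrogen now has a direct step of its own: replacing it with hydrogen, with nothing else altered, gives an 11-fold higher number from compound 2 to compound 3 (1.03 log units; beyond the scatter), a large change. The earlier pair could not show this, since those two compounds differ in more than one place. The other new step, a 1.9-fold lower number from compound 1 to compound 3 (0.28 log units; within the scatter), lies within the scatter, so without the side chain this assay does not separate the two drawn arrangements, and this comparison isolates a single kind of difference: the fact that compounds 1 and 3 differ only in the configuration as drawn

The compounds shown leave open which part of the side chain goes with the large step, since its amine and its hydroxyl leave together, and a plain acetyl group or a longer chain on the same nitrogen would help to divide the effect. Going by these compounds, it also remains open whether the same difference in configuration would stay within the scatter with the (3-amino-1-hydroxypropyl)carbonyl group in place.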